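Pyrazoline series: chloro to pyrrolidin-1-yl on the carbonyl arm

The compounds below may be only part of what the source reports. "The series", "measured", "known", "first", "only" and "open" are said of these compounds alone.

Three compounds of the series carry measured values. Compound 1 `CC1=NN(C(=O)COc2ccc(Cl)cc2)C(c2cc(Br)cc(Br)c2O)C1` gives 40200 nM in a functional assay on PC-3 cells (Homo sapiens) for cytotoxicity, read by MTT assay, with a stated time of 48 h; a lower number here means a stronger inhibitor, a higher number a weaker inhibitor. Compound 2 `CC(=O)Oc1ccccc1C1CC(C)=NN1C(=O)CCl` gives 3580 nM in the same test, and compound 3 `O=C(CCl)N1N=C(c2cc3ccccc3oc2=O)CC1c1ccccc1` gives 2980 nM. Compound 3 thus holds the lowest of the three numbers; the gap to compound 2 lies within the scatter of repeated measurements, so the two cannot be ordered against each other, whereas compound 1 stands well beyond the scatter with a clearly higher number. Among the compounds with values here, no pair of measured compounds differs in a single place, so no step within the measured set can be read directly.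

Compound 4 `O=C(CN1CCCC1)N1N=C(c2cc3ccccc3oc2=O)CC1c1ccccc1` has not yet been measured in this assay. It differs from compound 3 as follows: pyrrolidin-1-yl in place of chloro on a saturated chain carbon bound to a carbonyl carbon. The only reference for the (chloromethyl)carbonyl arm is compound 3 itself, and compound 2, which also carries that arm, sits on a different core; nothing in the measured set shows what the ((pyrrolidin-1-yl)methyl)carbonyl arm does. The expectation is that compound 4 gives a higher number than compound 3, by a step of a 2.7-fold higher number from compound 3 to compound 4 (0.43 log units; beyond the scatter), somewhat beyond the scatter. Compound 4 is therefore estimated at 8000 nM, with a range from 2500 nM to 30000 nM.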

Compound 4, half-maximal inhibitory concentration: 50200 nM
Beside the measured number, compound 4's estimate is 6.3-fold (0.80 log units) below it; the whole stated range lies below it.
By their numbers in this assay, from the lowest: compounds 3 and 2 (each within the scatter of the next); then compounds 1 and 4 (each within the scatter of the next).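

Within the data shown here, on the shared core, the saturated chain carbon bound to a carbonyl carbon is the first place where a single change can be read: in this assay, pyrrolidin-1-yl in place of chloro gives a 17-fold higher number from compound 3 to compound 4 (1.23 log units; beyond the scatter), a large step beyond the scatter. This place is therefore not indifferent to what it carries, and of the two arms seen on this core, the (chloromethyl)carbonyl arm goes with the lower number. No measurement at hand bears on what lies behind this step, so it stands as an observation on one pair of compounds.

Going by these compounds, whether the higher number goes with the ring of pyrrolidin-1-yl, with an amine nitrogen at this place, or with the departure of chloro stays open; an open-chain dimethylamino group, a morpholin-4-yl ring or a simple methyl group on the same carbon would help to separate these readings. Also open, on these data alone, is whether the same change would act alike on the core of compound 2, which carries the same (chloromethyl)carbonyl arm.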